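The source may report more compounds than this note shows. Statements on the series, on what has been measured and on what is new or still open speak of the compounds shown alone.

Working notes on the side chain on the aromatic nitrogen, followed in a toxicity assay on HT-29 cells (Homo sapiens) for cytotoxicity; a higher number here means that more compound is tolerated, a lower number that less compound is tolerated. Compound 1 `CCn1nc(C(=O)N[C@H]2COc3ccccc3N(C)C2=S)nc1Cc1ccccc1` gives > 100000 nM, which is a limit and not a number. Compound 2 `CCCCCn1nc(C(=O)N[C@H]2COc3ccccc3N(C)C2=S)nc1Cc1ccccc1` gives > 100000 nM, again a limit. Compound 3 `CC(C)CCn1nc(C(=O)N[C@H]2COc3ccccc3N(C)C2=S)nc1Cc1ccccc1` gives > 100000 nM, also a limit, so it has no exact standing in the series. The whole set reads as the limit of > 100000 nM in this assay, at which 3 of the 3 values shown sit.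

Compound 4 `COCCn1nc(C(=O)N[C@H]2COc3ccccc3N(C)C2=S)nc1Cc1ccccc1` has methoxy in place of isopropyl on a saturated chain carbon, two bonds along the chain from an aromatic nitrogen. The same difference reads as isopentyl to 2-methoxyethyl.

Within the data shown here, three measured steps bear on this change, and none has a size: a step that the two limits leave unreadable from compound 1 to compound 2, a step that the two limits leave unreadable from compound 1 to compound 3 and a step that the two limits leave unreadable from compound 2 to compound 3. No chain change so far has produced a number in this assay, so no direction can be taken from them.

The expected change is none beyond the scatter, and the estimated step is a number no higher from compound 3 to compound 4 (the limit leaves the size open). For compound 4 the estimated value is 100000 nM, with an expected range of 50000 nM to 100000 nM.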

Compound 4, half-maximal cytotoxic concentration: > 100000 nM
Compound 4 gave a limit, no number; the forecaster's own chance of this, stated with the estimate: 90%; the middle value lies on the limit itself.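

Among these compounds, compound 4 gives > 100000 nM as a limit and not a number, so no step linking it to compound 1, compound 2 or compound 3 can be read. The compounds shown leave open whether any of these side chains changes the tolerated concentration at all: the limit of > 100000 nM in this assay, at which 4 of the 4 values shown sit.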